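Replacing the 4-cyanobutyl chain of compound 3

The source may hold more compounds than are shown below. What is called first, only, known or untested is meant among the compounds shown, and "the series" means these compounds.

In a physicochemical assay for solubility, in phosphate buffer, with a stated time of 18 h (a higher number here means a more soluble compound, a lower number a less soluble compound), compound 1 `N#Cc1c(N)nc2nc(C3CCC3)ncc2c1N` gives 217000 nM, compound 2 `CCCCc1nc(C(C)(C)C)nc2nc(N)c(C#N)c(N)c12` gives 6000 nM, and compound 3 `CC(C)(C)c1nc(CCCCC#N)c2c(N)c(C#N)c(N)nc2n1` gives 16000 nM, the second highest of the three numbers. Compound 4 `CC(C)(C)c1nc(-c2nccs2)c2c(N)c(C#N)c(N)nc2n1` carries 1,3-thiazol-2-yl in place of 4-cyanobutyl on an aromatic carbon. For the measured compounds named here, the only measured step bearing on this place is a 2.7-fold higher number from compound 2 to compound 3 (0.43 log units; beyond the scatter), a modest one, made by a cyano group on the chain. Going by the values given here, no measured compound has an aromatic ring at that place, so this step guides the expected size only loosely. The expected change is a 2.3-fold lower number from compound 3 to compound 4 (0.36 log units; beyond the scatter), a modest fall. Compound 4 is estimated at 7000 nM, with an expected range of 2000 nM to 25000 nM.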

Compound 4, solubility: < 1500 nM
Compound 4 was reported as a limit; the forecaster's own chance of this, stated with the estimate: 3%; middle value at least 4.6-fold (0.66 log units) from the limit.
By their numbers in this assay, from the lowest: compound 2; then compound 3; then compound 1. At a limit, below all of these: compound 4.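

In this assay compound 4 is reported only as a limit, not as a number: the limit of < 1500 nM in this assay, at which 1 of the 4 values shown sits. At this place, 1,3-thiazol-2-yl gives an at least 10-fold lower number from compound 3 to compound 4 (1.02 log units; beyond the scatter), and in place of butyl it gives an at least 4.0-fold lower number from compound 2 to compound 4 (0.60 log units; beyond the scatter). The earlier compounds shown here showed only a change on the chain at this position, and these steps show that an aromatic ring there can shift the read-out further, in the downward direction.

As far as these compounds go, how low compound 4 truly lies stays open. So does whether a phenyl ring, a morpholine or an amine-bearing chain at this place would behave like 1,3-thiazol-2-yl.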